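The source may hold more compounds than are shown below. What is called first, only, known or untested is meant among the compounds shown, and "the series" means these compounds.

Measured so far:

Compound 1 `C=CS(=O)(=O)N1CCN(c2nc(OC[C@H]3CCCN3C)nc3sc(-c4ccc(N5CCN(C)CC5)cc4)cc23)CC1`: 540 nM
Compound 2 `CCS(=O)(=O)N1CCN(c2ncnc3sc(-c4ccc(N5CCN(C)CC5)cc4)cc23)CC1`: 10600 nM

Both compounds were tested in a functional assay on MDA-MB-436 cells (Homo sapiens) for antiproliferative activity, read by MTT assay, with a stated time of 48 h; a higher number here means a weaker inhibitor, a lower number a stronger inhibitor. Compound 2 has the higher of the two numbers, and the gap to compound 1 lies beyond the usual scatter, so compound 2 is the weaker of the two. Compound 1 and compound 2 differ in more than one place, so their gap cannot be tied to any single change.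

Compound 3 `CN1CCN(c2ccc(-c3cc4c(N5CCN(C(=O)Nc6ccc(F)cc6F)CC5)ncnc4s3)cc2)CC1` has not yet been measured in this assay. It differs from compound 2 in one place: (2,4-difluorophenyl)carbamoyl in place of ethylsulfonyl on an amine nitrogen in a ring. For the measured compounds named here, there is no measured pair that isolates this change, so any expectation rests on compound 2 alone. The number for compound 3 is expected to move to a lower value than that of compound 2, by a moderate step of a 3.5-fold lower number from compound 2 to compound 3 (0.55 log units; beyond the scatter), though a result within the scatter would not be surprising. Compound 3 is estimated at 3000 nM, within a range of 700 nM to 12000 nM.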

Compound 3, half-maximal inhibitory concentration: 20200 nM
For compound 3 the middle estimate is 6.7-fold (0.83 log units) below the measured one; the measured number lies above the stated range.
By their numbers in this assay, from the lowest: compound 1; then compounds 2 and 3 (each within the scatter of the next).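

In this assay, replacing ethylsulfonyl with (2,4-difluorophenyl)carbamoyl on the amine nitrogen gives a 1.9-fold higher number from compound 2 to compound 3 (0.28 log units; within the scatter), so this assay does not separate the two groups. The change is a large one in structure: the entering group has 11 heavy atoms against 5, and it adds an aromatic ring and a hydrogen-bond donor, yet the readout stays within the usual scatter. No supporting measurement explains this result.

The compounds shown leave open whether an acetyl group, a methyl group or a plain phenylcarbamoyl group on this nitrogen would give a clearly different number. From the compounds shown here alone, it also remains open whether (2,4-difluorophenyl)carbamoyl would behave the same way on the core of compound 1, which carries an additional side chain.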